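The source may hold more compounds than are shown below. What is called first, only, known or untested is meant among the compounds shown, and "the series" means these compounds.

Within the data shown here, compound 1 `CC(C)S(=O)(=O)N1CCN(c2cnn(-c3cccc(F)c3)c(=O)c2OC2CCCC2)CC1` gives 670 ng.h/mL in an ADME assay on the whole organism for pharmacokinetics, with Rattus norvegicus as the target, with a stated time of 6 h, at a dose of 10 mg/kg by the oral route (on this read-out higher numbers stand for higher exposure at the dose given and lower numbers for lower exposure), the higher of the two numbers measured so far; compound 2 `CC(C)S(=O)(=O)N1CCN(c2cnn(-c3cccc(F)c3)c(=O)c2OC2CCC(F)C2)CC1` gives 300 ng.h/mL, and the step of a 2.2-fold lower number from compound 1 to compound 2 (0.35 log units; beyond the scatter) is modest. Compound 3 `CC(C)S(=O)(=O)N1CCN(c2cnn(-c3ccccc3)c(=O)c2OC2CCCC2)CC1` differs from compound 1 by hydrogen in place of fluoro on an aromatic carbon. Among the measured compounds shown here, no measured step removes a fluoro from the aromatic ring; the single step available, a 2.2-fold lower number from compound 1 to compound 2 (0.35 log units; beyond the scatter), concerns a saturated ring carbon and so does not bear directly on this change. The expected step of a 1.2-fold lower number from compound 1 to compound 3 (0.09 log units; within the scatter) is therefore taken as none beyond the scatter. Compound 3 is estimated at 550 ng.h/mL, within a range from 200 ng.h/mL to 1500 ng.h/mL.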

Compound 3, area under the concentration-time curve: 1600 ng.h/mL
Compound 3: middle estimate off by 2.9-fold (0.46 log units), on the low side; the measured number lies above the stated range.
By their numbers in this assay, from the lowest: compound 2; then compound 1; then compound 3.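

Removing the aromatic fluoro is not neutral in this assay: the 3-fluorophenyl to phenyl change gives a 2.4-fold higher number from compound 1 to compound 3 (0.38 log units; beyond the scatter) and puts compound 3 at the top of the three. In both single-place steps, the compound carrying the added fluoro has the lower number, on the aromatic carbon here and on the saturated ring carbon in a 2.2-fold lower number from compound 1 to compound 2 (0.35 log units; beyond the scatter). Nothing available explains this difference.

Open, on these data alone, is whether a chloro or methoxy group on that aromatic carbon would read like fluoro or like hydrogen. Also open, as far as these compounds go, is whether removing the aromatic fluoro from compound 2 would give a step of similar size.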